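Phenyl for Isobutyl on a Weak Antiproliferative Sulfonamide

A few compounds are considered here, and "the series" means these few. Any claim that something is new, unique, unknown or untested is made for them only; others in the source may bear on it.

Compound 1 `Cc1ccc(S(=O)(=O)N2CC[C@@H](Cl)C[C@@H]2CC(C)C)cc1` gives 36000 nM in a functional assay on A2780 cells (Homo sapiens) for antiproliferative activity, read by sulforhodamine B assay, with a stated time of 48 h; a lower number here means a stronger inhibitor of growth, a higher number a weaker inhibitor of growth.
Compound 2 `Cc1ccc(S(=O)(=O)N2CC[C@@H](Br)C[C@@H]2CC(C)C)cc1` gives 39000 nM in this assay.

Compound 2 has the higher of the two numbers, but the step of a 1.1-fold higher number from compound 1 to compound 2 (0.03 log units; within the scatter) lies within the scatter, so the two compounds cannot be told apart. Compound 3 `Cc1ccc(S(=O)(=O)N2CC[C@@H](Br)C[C@@H]2c2ccccc2)cc1` differs from compound 2 by phenyl in place of isobutyl on a saturated ring carbon. Within the data shown here, no measured step involves such an exchange; the only known step swaps one halogen for another and is small. The expectation therefore rests on little, and a shift in either direction beyond the scatter remains possible. For compound 3 the value in this assay is expected near 25000 nM, between 6000 nM and 100000 nM. The expected step is a 1.6-fold lower number from compound 2 to compound 3 (0.19 log units; within the scatter).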

Compound 3, concentration for 50% growth inhibition: > 100000 nM
Compound 3: a limit, no number; the forecaster's own chance of this, stated with the estimate: 15%; at least 4.0-fold (0.60 log units) between middle value and limit.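

Compound 3 gives only a limit of the assay, not a number: the limit of > 100000 nM in this assay, at which 1 of the 3 values shown sits. Even so, phenyl in place of isobutyl gives an at least 2.5-fold higher number from compound 2 to compound 3 (0.40 log units; beyond the scatter), so the group on this saturated ring carbon, next to the ring nitrogen, can weaken growth inhibition beyond the scatter, something the halogen exchange elsewhere on the ring did not show. The compounds shown leave open whether a methyl, a longer chain or an amine at this carbon would give a stronger inhibitor than isobutyl does.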